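The source may hold more compounds than are shown below. What is called first, only, known or untested is meant among the compounds shown, and "the series" means these compounds.

In a physicochemical assay for solubility, using the shake flask method, in simulated intestinal fluid, measured as kinetic solubility, with a stated time of 2 h, at 25 degrees C, at pH 6.5 (on this read-out higher numbers stand for higher solubility and lower numbers for lower solubility), compound 3 `Cc1noc(-c2nc(C)c3c(c2N)C(=O)N(Cc2ccccc2Cl)C3=O)n1` gives < 5000 nM as a limit of the assay, not a number. Compound 1 `Cc1noc(-c2nc(C)c3c(c2N)C(=O)N(Cc2ccc(Br)cc2)C3=O)n1` gives < 5000 nM, which is also a limit. This is the limit of < 5000 nM in this assay, at which 2 of the 3 values shown sit. Only compound 2 `Cc1noc(-c2nc(C)c3c(c2N)C(=O)N(C(C)c2ccccc2)C3=O)n1` gives a true number in this assay, namely 10900 nM.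

The next change swaps 2-chlorophenyl for pyridin-4-yl on a saturated chain carbon bound to an amide-type nitrogen in a ring, which gives compound 4 `Cc1noc(-c2nc(C)c3c(c2N)C(=O)N(Cc2ccncc2)C3=O)n1`. Counted, the difference is pyridin-4-yl in place of 2-chlorophenyl on a saturated chain carbon bound to an amide-type nitrogen in a ring. Cut one bond further out, it reads 2-chlorobenzyl to (pyridin-4-yl)methyl.

Within the data shown here, two measured steps bear on this change: an at least 2.1-fold higher number from compound 1 to compound 2 (0.33 log units; beyond the scatter) and an at least 2.1-fold lower number from compound 2 to compound 3 (0.33 log units; beyond the scatter). The step between the two limits, a step that the two limits leave unreadable from compound 1 to compound 3, adds nothing. Among these three compounds, the two with chlorine or bromine on the phenyl ring sit at the limit, while compound 2, with neither, gives a number. None of the three goes against this, but three compounds are few. Compound 4 also has neither halogen, so a modest rise is expected, with the size of an at least 2.1-fold lower number from compound 2 to compound 3 (0.33 log units; beyond the scatter) as the guide, reversed in direction. The expected change is an at least 2.4-fold higher number from compound 3 to compound 4 (0.38 log units; beyond the scatter). A limit remains possible. For compound 4 the estimated solubility is 12000 nM, with an expected range from 5000 nM to 40000 nM.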

Compound 4, solubility: 26400 nM
The estimate for compound 4 lay 2.2-fold (0.34 log units) below the measured number; measured number inside the range.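

Compound 4 is the first compound shown with a nitrogen in the aromatic ring at this position, and in this assay its number is the highest of the four, with a 2.4-fold higher number from compound 2 to compound 4 (0.38 log units; beyond the scatter) as the one step here read between two true numbers. Among these compounds, this shows that a (pyridin-4-yl)methyl group on the ring nitrogen of the shared core can go beyond the only number seen before, not merely clear the limit. Against the two halogen-bearing compounds, the steps are an at least 5.2-fold higher number from compound 3 to compound 4 (0.72 log units; beyond the scatter) and an at least 5.2-fold higher number from compound 1 to compound 4 (0.72 log units; beyond the scatter), each starting from a limit and not from a number, and the split between halogen-free compounds with numbers and halogen-bearing compounds at the limit now holds across all four with none against it, though four compounds are still few: the limit of < 5000 nM in this assay, at which 2 of the 4 values shown sit.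

From the compounds shown here alone, whether the rise comes from losing the chlorine or from gaining the ring nitrogen stays open, and an unsubstituted benzyl group in the same place would help separate the two. Going by these compounds, it is also open whether pyridin-3-yl or pyridin-2-yl would read like pyridin-4-yl.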